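A few compounds are considered here, and "the series" means these few. Any claim that something is new, unique, unknown or untested is made for them only; others in the source may bear on it.

Working notes on a series that shares one core and differs in the aromatic group. In a functional assay on MCF7 cells (Homo sapiens) for cytotoxicity, read by sulforhodamine B assay (on this read-out higher numbers stand for weaker inhibition of growth and lower numbers for stronger inhibition of growth), compound 1 (`CC1=CC[C@@H]([C@@](C)(O)CCCC(C)(C)NC(=S)N/N=C\c2ccc(O)cc2)CC1`) gives 6230 nM, compound 2 (`CC1=CC[C@@H]([C@@](C)(O)CCCC(C)(C)NC(=S)N/N=C\c2ccc(N(C)C)cc2)CC1`) gives 14000 nM and compound 3 (`CC1=CC[C@@H]([C@@](C)(O)CCCC(C)(C)NC(=S)N/N=C\c2ccc([N+](=O)[O-])cc2)CC1`) gives 17700 nM. Compound 3 is not separated from its nearest neighbour, since the measured step is a 1.3-fold higher number from compound 2 to compound 3 (0.10 log units; within the scatter). It is separated from the hydroxy compound by a 2.8-fold higher number from compound 1 to compound 3 (0.45 log units; beyond the scatter), and the dimethylamino compound is separated from the hydroxy compound by a 2.2-fold higher number from compound 1 to compound 2 (0.35 log units; beyond the scatter); both of these steps are modest.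

Compound 4 (`CC1=CC[C@@H]([C@@](C)(O)CCCC(C)(C)NC(=S)N/N=C\c2cccc(Cl)c2)CC1`) brings 3-chlorophenyl in place of 4-nitrophenyl on a carbon with a double bond to nitrogen. For the measured compounds named here, no measured compound carries 3-chlorophenyl, so the three steps above bear on this change only indirectly. They show what exchanging a group on this aromatic ring has done so far in three compounds, and none goes past the modest size of the step to compound 3 from the hydroxy compound. No step beyond the scatter is therefore expected in this assay, and no firm direction can be assigned. The expected step is a 1.4-fold lower number from compound 3 to compound 4 (0.13 log units; within the scatter). Compound 4 is estimated at 13000 nM, with an expected range from 6000 nM to 28000 nM.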

Compound 4, concentration for 50% growth inhibition: 7350 nM
For compound 4 the middle estimate is 1.8-fold (0.25 log units) above the measured one, within the range that was stated.
By their numbers in this assay, from the lowest: compounds 1, 4, 2 and 3 (each within the scatter of the next, the first and the last beyond it).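

In this assay, 3-chlorophenyl in place of 4-nitrophenyl on a carbon with a double bond to nitrogen gives a 2.4-fold lower number from compound 3 to compound 4 (0.38 log units; beyond the scatter) and is a modest step beyond the scatter, so this exchange separates two compounds that carry different groups at both the group's identity and its printed ring position. Compound 4 is not separated from either of the other two compounds, with a 1.9-fold lower number from compound 2 to compound 4 (0.28 log units; within the scatter) and a 1.2-fold higher number from compound 1 to compound 4 (0.07 log units; within the scatter) both within the scatter, even though compound 1 and compound 2 are separated from each other by a 2.2-fold higher number from compound 1 to compound 2 (0.35 log units; beyond the scatter) and so compound 4 cannot be placed with either one. The series therefore now holds a group with 0 hydrogen-bond donors and 0 hydrogen-bond acceptors at a number not separated from that of compound 1, and no measurement on hand accounts for the step from 4-nitrophenyl to 3-chlorophenyl.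

The compounds shown leave open whether the step follows the chlorine itself or its place on the ring, since neither 4-chlorophenyl nor 3-nitrophenyl is among them. They also leave open how a ring bearing a carboxylic acid or a primary amine, or a saturated cyclohexyl group on the same carbon, would stand in this series.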